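From 4-chlorobenzyl to 2-chlorobenzyl

The compounds below may be only part of what the source reports. "The series", "measured", "known", "first", "only" and "open" are said of these compounds alone.

Values in a functional assay on HT-29 cells (Homo sapiens) for inhibition, read by MTT assay, with a stated time of 48 h; a higher number here means a weaker inhibitor, a lower number a stronger inhibitor:
- compound 1 `COc1ccc(C/N=C2\NC(=O)/C(=C3\CCNC(=O)c4[nH]ccc43)S2)cc1`: 11500 nM
- compound 2 `O=C1N/C(=N\Cc2ccc(C(F)(F)F)cc2)S/C1=C1/CCNC(=O)c2[nH]ccc21`: > 50000 nM (a limit)
- compound 3 `O=C1N/C(=N\Cc2ccc(Cl)cc2)S/C1=C1/CCNC(=O)c2[nH]ccc21`: > 100000 nM (a limit)

Compound 3 gives only a limit (> 100000 nM) and no number. Compound 4 `O=C1N/C(=N\Cc2ccccc2Cl)S/C1=C1/CCNC(=O)c2[nH]ccc21` carries 2-chlorophenyl in place of 4-chlorophenyl on a saturated chain carbon bound to a double-bonded nitrogen. Among the measured compounds shown here, no measured step moves a group in this way. The nearest are an at least 8.6-fold higher number from compound 1 to compound 3 (0.93 log units; beyond the scatter) and an at least 4.3-fold higher number from compound 1 to compound 2 (0.63 log units; beyond the scatter) as changes of group, while a step that the two limits leave unreadable from compound 2 to compound 3 gives no size. Compound 4 keeps the chloro of compound 3 (an at least 8.6-fold higher number from compound 1 to compound 3 (0.93 log units; beyond the scatter)), so weak inhibition is expected, with a modest step towards a lower number as the only readable direction. The expected step is an at least 1.4-fold lower number from compound 3 to compound 4 (0.15 log units; that floor lies within the scatter) in this assay and remains uncertain. For compound 4 the estimated value is 70000 nM with an expected range of 20000 nM to 200000 nM in this assay.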

Compound 4, half-maximal inhibitory concentration: > 100000 nM
Compound 4: a limit, no number; the forecaster's own chance of this, stated with the estimate: 55%; at least 1.4-fold (0.15 log units) between middle value and limit.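

In this assay compound 4 gives > 100000 nM, which is a limit, so moving the chloro from 4-chlorophenyl to 2-chlorophenyl at this place still yields no number. Replacing 4-methoxyphenyl with 2-chlorophenyl gives an at least 8.6-fold higher number from compound 1 to compound 4 (0.93 log units; beyond the scatter), so this chloro placement does not recover the value of the methoxy compound. The steps among the limit values cannot be read: the limit of > 100000 nM in this assay, at which 2 of the 4 values shown sit.

Whether a number returns depends on groups not shown here. On these data alone, it remains open whether 2-methoxyphenyl or 4-hydroxyphenyl at this place would give a measurable value.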